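The compounds below may be only part of what the source reports. "The series", "measured", "known", "first", "only" and "open" are said of these compounds alone.

In a functional assay on HL-60 cells (Homo sapiens) for antiproliferative activity, read by MTT assay, with a stated time of 24 h (a lower number here means a stronger inhibitor, a higher number a weaker inhibitor), three compounds on one shared core have been measured: compound 1 `CCCCc1oc2ccccc2c1C(=O)c1ccc(OCCCC(=O)N2CCCCC2)cc1` gives 31900 nM and compound 2 `CCCCc1oc2ccccc2c1C(=O)c1ccc(OCCCC(=O)N2CCOCC2)cc1` gives 34100 nM and compound 3 `CCCCc1oc2ccccc2c1C(=O)c1ccc(OCCCC(=O)NCc2ccccc2)cc1` gives 28900 nM so that compound 3 stands level with both others within the scatter. Compound 4 `CCCCc1oc2ccccc2c1C(=O)c1ccc(OCCCC(=O)N[C@@H](C)c2ccccc2)cc1` differs from compound 3 by a single change (methyl in place of hydrogen on a saturated chain carbon bound to an amide-type nitrogen and an aromatic carbon) that turns benzylamino into (1-phenylethyl)amino. Among the compounds with values here, three measured steps bear on it only indirectly. Each swaps the whole group on the carbonyl carbon, and a 1.1-fold lower number from compound 1 to compound 3 (0.04 log units; within the scatter) and a 1.2-fold lower number from compound 2 to compound 3 (0.07 log units; within the scatter) and a 1.1-fold higher number from compound 1 to compound 2 (0.03 log units; within the scatter) all stay within the scatter. Within the data shown here, no measured pair tests a methyl on this chain carbon, so the data hold no direct precedent. Compound 3 at 28900 nM is therefore the anchor, and no step beyond the scatter is expected in this assay in either direction. The expected step of a 1.0-fold lower number from compound 3 to compound 4 (0.01 log units; within the scatter) stays within the scatter. Compound 4 is estimated to give 28000 nM (expected range 15000 nM to 50000 nM).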

Compound 4, half-maximal inhibitory concentration: > 50000 nM
Compound 4: a limit, no number; the forecaster's own chance of this, stated with the estimate: 10%; middle value at least 1.7-fold (0.25 log units) away from the limit.
By their numbers in this assay, from the lowest: compounds 3, 1 and 2 (each within the scatter of the next). At a limit, above all of these: compound 4.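

In this assay compound 4 is recorded as a limit, not a number: the limit of > 50000 nM in this assay, at which 1 of the 4 values shown sits. The methyl on the saturated chain carbon bound to an amide-type nitrogen and an aromatic carbon gives an at least 1.7-fold higher number from compound 3 to compound 4 (0.23 log units; that floor lies within the scatter), and the wider swaps give an at least 1.5-fold higher number from compound 1 to compound 4 (0.19 log units; that floor lies within the scatter) and an at least 1.4-fold higher number from compound 2 to compound 4 (0.16 log units; that floor lies within the scatter). Within the data shown here, each of these floors lies within the scatter, so the result does not establish a real loss, but this is the first change whose step has no upper bound, whereas the swaps among compounds 1, 2 and 3 all stayed within the scatter.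

Going by these compounds, how far compound 4 truly lies from the other compounds stays open. So does whether an ethyl or a hydroxymethyl on the same carbon, or the mirror-image (1-phenylethyl)amino group, would read the same way.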